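Capping the remaining hydroxy of compound 2

The source may hold more compounds than are shown below. What is called first, only, known or untested is meant among the compounds shown, and "the series" means these compounds.

In a functional assay on A549 cells (Homo sapiens) for inhibition, read by MTT assay, with a stated time of 72 h (on this read-out higher numbers stand for weaker inhibition and lower numbers for stronger inhibition), compound 2 `CO[C@@H](c1ccccc1)[C@H]1O[C@@H]2CC(=O)O[C@@H]2[C@H]1O` gives 5310 nM and so lies within the scatter of compound 3 `CO[C@H](c1ccccc1)[C@H]1O[C@@H]2CC(=O)O[C@@H]2[C@H]1O` (2640 nM), while compound 1 `CO[C@@H]1[C@H]2OC(=O)C[C@H]2O[C@@H]1[C@@H](O)c1ccccc1` reads clearly higher (38300 nM). Compound 4 `CO[C@@H]1[C@H]2OC(=O)C[C@H]2O[C@@H]1[C@@H](OC)c1ccccc1` differs from compound 2 by methyl in place of hydrogen on an oxygen on a saturated carbon (hydroxy to methoxy, methyl in place of hydrogen on an oxygen on a saturated carbon). For the measured compounds named here, the only measured step (a 2.0-fold lower number from compound 2 to compound 3 (0.30 log units; within the scatter)) is a change of configuration and gives no direct guide to this methylation. Compound 4 shares this new methoxy with compound 1 (38300 nM), which offers a weak hint of a higher number. In this assay the estimated step (a 2.3-fold higher number from compound 2 to compound 4 (0.35 log units; beyond the scatter)) is therefore expected to be upward but remains uncertain. For compound 4 the expected value is 12000 nM within an estimated range from 3500 nM to 40000 nM on this read-out.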

Compound 4, half-maximal inhibitory concentration: 25100 nM
Compound 4: the middle estimate sits 2.1-fold (0.32 log units) below what was measured, within the range that was stated.
By their numbers in this assay, from the lowest: compounds 3 and 2 (each within the scatter of the next); then compounds 4 and 1 (each within the scatter of the next).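

In this assay, for the compounds shown here, turning this hydroxy into methoxy gives a 4.7-fold higher number from compound 2 to compound 4 (0.67 log units; beyond the scatter) as a modest step, the first direct reading of this change at this position. Going by these compounds alone, the same kind of capping on the other hydroxy, the one left free in compound 1, gives a 1.5-fold lower number from compound 1 to compound 4 (0.18 log units; within the scatter) and so stays within the scatter, which means the two hydroxy groups do not respond alike in these two steps. Nothing in the information shown explains this difference. On these data alone, it remains open how a longer chain such as ethyl on this oxygen, or an amine in place of the hydroxy, would read.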